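The source may report more compounds than this note shows. Statements on the series, on what has been measured and on what is new or still open speak of the compounds shown alone.

Compound 3 `O=C(O)CC/C=C\C[C@@H]1CN(S(=O)(=O)c2cccc3ccccc23)C[C@@H]1c1ccccc1O` gives 1.59 nM in a functional assay (Cavia porcellus) for antagonist activity at thromboxane A2 receptor (Homo sapiens) (on this read-out lower numbers stand for tighter binding and higher numbers for weaker binding), the lowest of the three numbers measured. The nearest is compound 2 `O=C(O)CCC/C=C\C[C@@H]1CN(S(=O)(=O)c2cccc3ccccc23)C[C@@H]1c1ccccc1O`, which in this assay gives 6.31 nM; the furthest is compound 1 `O=C(O)CC/C=C\C[C@@H]1CN(Cc2cccnc2)C[C@@H]1c1ccccc1O`, which gives 1580 nM. For the measured compounds named here, the one single-point step measured so far, a 4.0-fold lower number from compound 2 to compound 3 (0.60 log units; beyond the scatter), concerns the chain, not the aromatic group on the sulfonyl sulfur.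

Compound 4 `O=C(O)CC/C=C\C[C@@H]1CN(S(=O)(=O)c2cccc3cnccc23)C[C@@H]1c1ccccc1O` differs from compound 3 by isoquinolin-5-yl in place of naphthalen-1-yl on a sulfonyl sulfur. Going by the values given here, no measured step changes the aromatic group on the sulfonyl sulfur, so nothing among the measured compounds speaks directly to this move; compounds 1 and 2 only show that the carboxylic chain and the substituent on the ring nitrogen matter. Among the compounds with values here, with no bearing step, the expected change in this assay from compound 3 to compound 4 is a 1.6-fold higher number from compound 3 to compound 4 (0.20 log units; within the scatter), that is none beyond the scatter. Compound 4 is therefore estimated at 2.5 nM, with a range of 0.8 nM to 8 nM.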

Compound 4, dissociation constant: 0.316 nM
For compound 4 the middle estimate is 7.9-fold (0.90 log units) above the measured one, and the stated range ends above it.
By their numbers in this assay, from the lowest: compound 4; then compound 3; then compound 2; then compound 1.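

The aromatic group on the sulfonyl sulfur turns out to be a place where a single exchange moves the number in this assay: isoquinolin-5-yl in place of naphthalen-1-yl gives a 5.0-fold lower number from compound 3 to compound 4 (0.70 log units; beyond the scatter). The two groups hold the same count of heavy atoms, so the step comes with one ring carbon exchanged for a nitrogen, which adds one hydrogen-bond acceptor, and not with a larger group. Nothing measured on hand explains why this exchange lowers the number.

The compounds shown leave open whether quinolin-5-yl or a single phenyl ring on the sulfonyl sulfur would behave like isoquinolin-5-yl. They also leave open whether the same exchange would give a similar step on the longer chain of compound 2.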